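This account rests on a few compounds, and the source may have more. Where it says the series, first, only, none or still open, it means among the compounds named here.

Measured in a functional assay on A549 cells (Homo sapiens) for cytotoxicity; on this read-out higher numbers stand for weaker inhibition and lower numbers for stronger inhibition:

- compound 1 `Cc1ccc(C2CN(S(=O)(=O)c3ccccc3)C(=O)N2)cc1`: > 316000 nM (a limit of the assay)
- compound 2 `O=C1NC(c2ccc(Br)cc2)CN1S(=O)(=O)c1ccc(Cl)cc1`: 161000 nM

Among the compounds with values here, compound 2 holds the only actual number in this small set, and it shows very weak inhibition in this assay. The entry for compound 1 is a limit and not a number, so no true comparison can be drawn from it.

The next compound, compound 3 `Cc1ccc(C2CN(S(=O)(=O)c3ccc(Cl)cc3)C(=O)N2)cc1`, differs from compound 2 at a single place, with methyl in place of bromo on an aromatic carbon. Within the data shown here, no measured pair isolates this change, so its size has to be judged without a direct precedent.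

Starting from compound 2 at 161000 nM, a small move towards weaker inhibition is expected, perhaps none beyond the usual scatter. The expected change is a 1.4-fold higher number from compound 2 to compound 3 (0.14 log units; within the scatter). Compound 3 could also end up at the limit of > 316000 nM in this assay, at which 1 of the 2 values shown sits, and that outcome would be expected to give no number. For compound 3 the estimate is 220000 nM, with an expected range from 100000 nM to 450000 nM.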

Compound 3, half-maximal inhibitory concentration: 158000 nM
For compound 3 the middle estimate is 1.4-fold (0.14 log units) above the measured one, and the stated range covers the measured number.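

In this assay, the exchange of 4-bromophenyl for 4-methylphenyl gives a 1.0-fold lower number from compound 2 to compound 3 (0.01 log units; within the scatter), so on this aromatic carbon, para to a large group, the read-out does not tell bromo and methyl apart. The second step, with chloro in place of hydrogen on an aromatic carbon, gives an at least 2.0-fold lower number from compound 1 to compound 3 (0.30 log units; that floor lies within the scatter), and as that floor lies within the scatter, it does not establish that chloro changes the result at this other place. Compound 1 remains a limit of the assay and not a number, which leaves the true size of that step unknown: the limit of > 316000 nM in this assay, at which 1 of the 3 values shown sits.

The compounds shown leave open whether an amine or a carboxylic acid on the aromatic carbon that carries bromo in compound 2 and methyl in compound 3 would move the number beyond the scatter. They also leave open how far the chloro step really reaches, and whether a longer chain in place of chloro would give a readable number in this assay.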